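The source may report more compounds than this note shows. Statements on the series, on what has been measured and on what is new or still open speak of the compounds shown alone.

Measured so far:
Compound 1, `O=C(CCN1C(=O)CSc2ccccc21)N1CCN(c2ccccc2F)CC1`: 1600 nM in a functional assay on MDA-MB-231 cells (Homo sapiens) for inhibition, read by sulforhodamine B assay, with a stated time of 48 h; on this read-out higher numbers stand for weaker inhibition of growth and lower numbers for stronger inhibition of growth.
Compound 2, `O=C(CCN1C(=O)CSc2ccccc21)NCCCN1CCN(c2ccc([N+](=O)[O-])cc2)CC1`: in this assay compound 2 gives only > 100000 nM, a limit rather than a number.

Compound 2 thus stands at the limit of > 100000 nM in this assay, at which 1 of the 2 values shown sits. For the measured compounds named here, no step between the two measured compounds is given.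

Compound 3, `O=C(CCN1C(=O)CSc2ccccc21)NCCCN1CCN(c2ccccc2)CC1`, awaits measurement in this assay. It differs from compound 2 by hydrogen in place of nitro on an aromatic carbon. Going by the values given here, with no measured step to lean on, the author expects at most a modest move toward stronger inhibition of growth, possibly none beyond the scatter. For compound 3 in this assay the estimate is 60000 nM, within 10000 nM to 300000 nM, an expected step of an at least 1.6-fold lower number from compound 2 to compound 3 (0.22 log units; that floor lies within the scatter).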

Compound 3, concentration for 50% growth inhibition: < 10 nM
Compound 3 was reported as a limit (the forecaster's own chance of this, stated with the estimate: 50%); middle value at least 6000-fold (3.77 log units) away from the limit.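

For the compounds shown here, replacing nitro with hydrogen on the aromatic carbon para to a large group gives an at least 10000-fold lower number from compound 2 to compound 3 (4.00 log units; beyond the scatter), the first step in this assay and one that shows this single place can decide between no measurable growth inhibition and very strong inhibition. Compound 2 stands at > 100000 nM, which is a limit and not a number. Going by these compounds, compound 3 stands at < 10 nM, also a limit, so the full size of the step stays unknown.

On these data alone, whether an amine, a methoxy group or a chlorine atom at this place would bring a value nearer compound 3 or compound 2 remains open. Also open, as far as these compounds go, is what a longer chain would do to compound 3.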